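Hydrazone aryl swap on the shared core, compound 1 to compound 3

The compounds below may be only part of what the source reports. "The series", "measured", "known", "first", "only" and "open" are said of these compounds alone.

Among the compounds with values here, two hydrazones on the shared core have numbers so far. Compound 1 `Cn1c(=O)c(=O)n(C2CCCC2)c2nc(N/N=C/c3ccco3)ncc21` carries a furan-2-yl on the hydrazone carbon; in a functional assay on PC-3 cells (Homo sapiens) for antiproliferative activity, read by MTT assay (a lower number here means a stronger inhibitor, a higher number a weaker inhibitor), compound 1 gives 72200 nM, the highest number of the two. Compound 2 `Cn1c(=O)c(=O)n(C2CCCC2)c2nc(N/N=C/c3cc(C(F)(F)F)cc(C(F)(F)F)c3)ncc21` carries a 3,5-bis(trifluoromethyl)phenyl in the same place and in this assay compound 2 gives 8200 nM, a lower number than compound 1 by a margin beyond the scatter.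

Compound 3 `Cn1c(=O)c(=O)n(C2CCCC2)c2nc(N/N=C/c3cccc([N+](=O)[O-])c3)ncc21` is the next member to be run. Relative to compound 1 the change is 3-nitrophenyl in place of furan-2-yl on a carbon with a double bond to nitrogen. Within the data shown here, no step between two measured compounds covers this exact exchange, so the expectation rests on the pair already seen: the six-membered carbon-only ring with substituents in compound 2 sits well below compound 1, and compound 3 brings in a ring of that kind.

The step from compound 1 to compound 3 is therefore expected to go downward, a 3.3-fold lower number from compound 1 to compound 3 (0.52 log units; beyond the scatter), of moderate size rather than all the way to compound 2. For compound 3 the estimate in this assay is 22000 nM, within 7000 nM to 65000 nM.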

Compound 3, half-maximal inhibitory concentration: 20300 nM
The estimate for compound 3 lay 1.1-fold (0.03 log units) above the measured number, within the range that was stated.
By their numbers in this assay, from the lowest: compound 2; then compound 3; then compound 1.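

In this assay, exchanging furan-2-yl for 3-nitrophenyl gives a 3.6-fold lower number from compound 1 to compound 3 (0.55 log units; beyond the scatter), so this position now has two six-membered aromatic rings of carbon only, each with a lower number than the furan-2-yl of compound 1. The two rings do not read alike: compound 3 gives 20300 nM and compound 2 gives 8200 nM, so in these three compounds the number at this position follows the substituents on the ring as well as the kind of ring. Nothing measured here bears on the reason for the step from furan-2-yl to 3-nitrophenyl.

Going by these compounds, it remains open whether a plain phenyl on this carbon would already reach the number of compound 3, which would separate the contribution of the ring from that of its nitro substituent. Also open, on these data alone, is how the series would read in this assay with an amine or a carboxylic acid on the ring in place of the nitro group.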